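Swapping the indole for a methylsulfanylphenyl on the sulfone scaffold

A few compounds are considered here, and "the series" means these few. Any claim that something is new, unique, unknown or untested is made for them only; others in the source may bear on it.

Measured compounds:
compound 1 `Cc1ccc(CS(=O)(=O)/C(=C/c2c[nH]c3ccccc23)C(=O)c2ccc(Cl)cc2)cc1` — 25000 nM
compound 2 `CSc1ccc(/C=C(\C(=O)c2ccc(Cl)cc2)S(=O)(=O)Cc2ccc(Cl)cc2)cc1` — 10000 nM
compound 3 `Cc1ccc(CS(=O)(=O)/C(=C/c2c[nH]c3ccc(Br)cc23)C(=O)c2ccc(Cl)cc2)cc1` — 10000 nM

In a functional assay on DU-145 cells (Homo sapiens) for inhibition, read by trypan blue exclusion, with a stated time of 96 h (on this read-out higher numbers stand for weaker inhibition of growth and lower numbers for stronger inhibition of growth), compound 3 stands level with compound 2 at the digits given, the two of them together the lowest numbers of the three; compound 1 is furthest away, with a higher number. Among the measured compounds shown here, the only single-point step measured, a 2.5-fold lower number from compound 1 to compound 3 (0.40 log units; beyond the scatter), is modest. Compound 4 `CSc1ccc(/C=C(\C(=O)c2ccc(Cl)cc2)S(=O)(=O)Cc2ccc(C)cc2)cc1` has not yet been measured. It differs from compound 3 by 4-(methylsulfanyl)phenyl in place of 5-bromo-1H-indol-3-yl on a double-bonded chain carbon bound to a double-bonded chain carbon. For the measured compounds named here, no measured step covers this change; compound 2, which also carries the entering group, and compound 1 give the two extremes of what the values so far show. Compound 4 is therefore expected near the middle of the measured range, about 15000 nM, between 6000 nM and 40000 nM, which would mean a step of a 1.5-fold higher number from compound 3 to compound 4 (0.18 log units; within the scatter) that is expected to stay within the scatter.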

Compound 4, concentration for 50% growth inhibition: 10000 nM
Compound 4: middle estimate off by 1.5-fold (0.18 log units), on the high side; low and high end bracket the measured number.
By their numbers in this assay, from the lowest: compounds 2, 3 and 4 (each within the scatter of the next); then compound 1.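

In this assay, 4-(methylsulfanyl)phenyl can take the place of 5-bromo-1H-indol-3-yl on a double-bonded chain carbon bound to a double-bonded chain carbon, with no change at the digits printed from compound 3 to compound 4 (within the scatter) for this swap. Set against the indole without bromo, the same group gives a 2.5-fold lower number from compound 1 to compound 4 (0.40 log units; beyond the scatter) for the change, the same size of step as adding bromo to that indole. Methyl in place of chloro on an aromatic carbon shows no change at the digits printed from compound 2 to compound 4 (within the scatter) in this comparison. No supporting data explain these results. From the compounds shown here alone, whether an amine or a carboxylic acid in place of that methyl would shift the number remains open.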